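This account rests on a few compounds, and the source may have more. Where it says the series, first, only, none or still open, it means among the compounds named here.

Compound 1 `C[C@]1(O)C[C@](c2ccc(OC(F)(F)F)cc2)([C@H](O)c2ccccn2)C1`: in an assay on HEK293 cells for antagonist activity at transient receptor potential cation channel subfamily V member 3 (Homo sapiens), read by FLIPR and calcium flux (a lower number here means a stronger inhibitor, a higher number a weaker inhibitor), compound 1 gives 1510 nM.
Compound 2 `C[C@]1(O)C[C@@](c2ccc(C(F)(F)F)cc2)([C@H](O)c2ccccn2)C1`: in this assay compound 2 gives 840 nM.
Compound 3 `C[C@]1(O)C[C@@](c2ccc(OC(F)(F)F)cc2)([C@H](O)c2ccccn2)C1`: in this assay compound 3 gives 330 nM.

Compound 3 gives the lowest of the three numbers, with compound 2 nearest and compound 1 furthest. Compound 4 `C[C@]1(O)C[C@@](c2ccc(OC(F)(F)F)cc2)([C@@H](O)c2ccccn2)C1` keeps every atom and bond of compound 3: the two compounds have the same atoms and bonds and differ only in configuration as drawn: 2 of 3 stereo elements differ; a stereocentre at a saturated ring carbon is drawn R in compound 3 and S in compound 4; a stereocentre at a saturated chain carbon is drawn S in compound 3 and R in compound 4. Within the data shown here, only one measured step concerns configuration alone, a 4.6-fold lower number from compound 1 to compound 3 (0.66 log units; beyond the scatter), and it rests on (the fact that compounds 1 and 3 differ only in the configuration as drawn). The other step, a 2.5-fold lower number from compound 2 to compound 3 (0.41 log units; beyond the scatter), swaps a group and does not bear on configuration. Since altering two stereo elements already moved the number beyond the scatter, a further alteration of two is expected to move it again, here upward, as compound 4 leaves the arrangement that gave the lowest number. Compound 4 is therefore expected to give 1000 nM, between 300 nM and 4000 nM. The expected step is a 3.0-fold higher number from compound 3 to compound 4 (0.48 log units; beyond the scatter).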

Compound 4, antagonist equilibrium constant: > 10400 nM
Compound 4: only a limit was reported; the forecaster's own chance of this, stated with the estimate: 10%; middle value at least 10-fold (1.01 log units) from the limit.
By their numbers in this assay, from the lowest: compound 3; then compounds 2 and 1 (each within the scatter of the next). At a limit, above all of these: compound 4.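

Compound 4 reaches only a limit (> 10400 nM). Configuration alone can thus give a large step (an at least 31-fold higher number from compound 3 to compound 4 (1.49 log units; beyond the scatter)), and nothing else separates this pair: (the fact that compounds 3 and 4 differ only in the configuration as drawn). A second configuration step points the same way (an at least 6.8-fold higher number from compound 1 to compound 4 (0.83 log units; beyond the scatter)), and in both steps the saturated chain carbon goes from S to R. Each of these steps alters two stereo elements at once, which leaves the share of each element open. As far as these compounds go, how an amine in place of the hydroxyl on that chain carbon would read also remains open.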